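The compounds below may be only part of what the source reports. "The series", "measured", "known", "first", "only" and "open" are said of these compounds alone.

In an in vitro assay on cells for binding affinity to myelin-associated glycoprotein (Mus musculus), read by surface plasmon resonance (a higher number here means weaker binding, a lower number tighter binding), compound 1 `O=C(CCl)N[C@H]1[C@H]([C@@H](O)[C@H](O)CNC(=O)c2ccc(Cl)cc2)O[C@@](OCc2cccc(F)c2F)(C(=O)O)C[C@@H]1O` gives 2100 nM and compound 2 `O=C(NC[C@@H](O)[C@H](O)[C@@H]1O[C@@](OCc2cccc(F)c2F)(C(=O)O)C[C@H](O)[C@H]1NS(=O)(=O)c1ccccc1[N+](=O)[O-])c1ccc(Cl)cc1` gives 1400 nM. Compound 2 stands beside compound 1 with only a 1.5-fold lower number from compound 1 to compound 2 (0.18 log units; within the scatter), so the two are not separated. Compound 3 `CS(=O)(=O)N[C@H]1[C@H]([C@@H](O)[C@H](O)CNC(=O)c2ccc(Cl)cc2)O[C@@](OCc2cccc(F)c2F)(C(=O)O)C[C@@H]1O` keeps the sulfonamide of compound 2 and carries methyl in place of 2-nitrophenyl on a sulfonyl sulfur. Among the measured compounds shown here, no measured step touches the group on the sulfonyl sulfur; the one step at this nitrogen, a 1.5-fold lower number from compound 1 to compound 2 (0.18 log units; within the scatter), lay within the scatter. For compound 3 the expectation is therefore a 1.4-fold higher number from compound 2 to compound 3 (0.15 log units; within the scatter), with no direction beyond the scatter. Compound 3 is estimated at 2000 nM in this assay, in the range 900 nM to 4500 nM.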

Compound 3, dissociation constant: 17000 nM
Compound 3: middle estimate off by 8.5-fold (0.93 log units), on the low side, outside the stated range (above it).
By their numbers in this assay, from the lowest: compounds 2 and 1 (each within the scatter of the next); then compound 3.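

In this assay the group on the sulfonyl sulfur matters: methyl in place of 2-nitrophenyl gives a 12-fold higher number from compound 2 to compound 3 (1.08 log units; beyond the scatter), whereas the earlier change on this nitrogen stayed within the scatter. A sulfonamide on this nitrogen does not by itself hold the number down, as methylsulfonyl in place of (chloromethyl)carbonyl also gives an 8.1-fold higher number from compound 1 to compound 3 (0.91 log units; beyond the scatter). No measurement shown accounts for either step.

On these data alone, it remains open whether the step follows the aromatic ring or the nitro group. A plain phenyl or a longer alkyl chain on the sulfonyl sulfur would separate these.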